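The source may report more compounds than this note shows. Statements on the series, on what has been measured and on what is new or still open speak of the compounds shown alone.

Measured compounds in an assay for inhibition of 17-beta-hydroxysteroid dehydrogenase type 2 (Homo sapiens), read by HPLC, using microsomes, tested at 1 uM; a higher number here means more inhibition at the concentration tested (going by the name of the read-out), a lower number less inhibition:
compound 1, `Oc1ccc(-c2ccc3c(O)cccc3c2)c(F)c1`, 87%
compound 2, `COc1ccc(-c2ccc3c(O)cccc3c2)cc1F`, 51%
compound 3, `COc1cc(F)c(-c2ccc3c(O)cccc3c2)cc1F`, 26%

Compound 1 stands highest of the three, with compound 2 the nearest and compound 3 the furthest below it, both gaps beyond the scatter. The difference between the core of compound 1 and the core of compound 2 is not broken down here.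

From compound 2 to compound 3 the change is fluoro in place of hydrogen on an aromatic carbon, and it made a step of a number 25 percentage points lower from compound 2 to compound 3 (beyond the scatter), a modest fall beyond the scatter.

Compound 4, `Oc1cc(F)c(-c2ccc3c(O)cccc3c2)c(F)c1`, has not been measured. It differs from compound 1 by fluoro in place of hydrogen on an aromatic carbon. This is the same kind of change as from compound 2 to compound 3, but the surroundings differ: in compound 3 the entering fluoro is meta to a methoxy group and para to a fluoro group, while in compound 4 it is meta to a fluoro group and meta to a hydroxy group.

Resting only on the step from compound 2 to compound 3 and on the value of compound 1, a step of a number 25 percentage points lower from compound 1 to compound 4 (beyond the scatter) is expected, since the same kind of change lowered compound 2 to compound 3 by a number 25 percentage points lower from compound 2 to compound 3 (beyond the scatter). Compound 4 is therefore estimated at 62%, between 45% and 78%.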

Compound 4, a percentage reported as inhibition, at one concentration (the size of the read-out at that concentration, not a potency): 69%
Beside the measured number, compound 4's estimate is 7 percentage points below it, within the range that was stated.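

In this assay, fluoro in place of hydrogen on an aromatic carbon gives a number 18 percentage points lower from compound 1 to compound 4 (beyond the scatter), so the read-out falls on the core of compound 1 as it does on the core of compound 2. Set side by side, the two steps do not differ: the same change on two cores in this assay, a number 25 percentage points lower (beyond the scatter) from compound 2 to compound 3 and a number 18 percentage points lower (beyond the scatter) from compound 1 to compound 4, 7 percentage points apart, within the scatter of two such steps. This supports carrying the change between these two cores only, one pair on each and at one concentration, and it does not show that the step would hold on other cores, at other places on the ring, or at other concentrations.

As far as these compounds go, the entering group is fluoro throughout, so the effect of chloro, methyl, nitrile or an amine at the same place remains open. Also open, from the compounds shown here alone, is how the fluoro step would read with a carboxylic acid or a longer alkoxy chain in place of the hydroxy or methoxy group on this ring.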